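A few compounds are considered here, and "the series" means these few. Any claim that something is new, unique, unknown or untested is made for them only; others in the source may bear on it.

Measured in a functional assay on A2780 cells (Homo sapiens) for antiproliferative activity, read by resazurin assay, with a stated time of 72 h; a higher number here means a weaker inhibitor, a lower number a stronger inhibitor:
- compound 1 `CN(Cc1ccccc1Br)C(=O)c1cc2c(Cc3ccccc3)n[nH]c2cc1O`: 1200 nM
- compound 2 `Cc1ccc(CN(C)C(=O)c2cc3c(Cc4ccccc4)n[nH]c3cc2O)cc1`: 6900 nM

Compound 2 holds the higher of the two numbers, so it is the weaker inhibitor of the pair. Compound 3 `COc1cccc(CN(C)C(=O)c2cc3c(Cc4ccccc4)n[nH]c3cc2O)c1OC` differs from compound 2 by 2,3-dimethoxyphenyl in place of 4-methylphenyl on a saturated chain carbon bound to an amide-type nitrogen. Within the data shown here, one measured step bears on this change, since it alters the same place: a 5.8-fold higher number from compound 1 to compound 2 (0.76 log units; beyond the scatter), modest but beyond the scatter. Among the measured compounds shown here, with only that step as a guide, a modest move toward a lower number is expected in this assay, though not one reaching past compound 1. The expected step is a 2.3-fold lower number from compound 2 to compound 3 (0.36 log units; beyond the scatter). For compound 3 the estimate is 3000 nM, with an expected range of 1000 nM to 9000 nM.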

Compound 3, half-maximal inhibitory concentration: 4800 nM
For compound 3 the middle estimate is 1.6-fold (0.20 log units) below the measured one; measured number inside the range.
By their numbers in this assay, from the lowest: compound 1; then compounds 3 and 2 (each within the scatter of the next).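

In this assay, 2,3-dimethoxyphenyl in place of 4-methylphenyl gives a 1.4-fold lower number from compound 2 to compound 3 (0.16 log units; within the scatter), so a group of 10 heavy atoms with 2 hydrogen-bond acceptors does not separate from one of 7 heavy atoms with none. Set against 2-bromophenyl, the same group gives a 4.0-fold higher number from compound 1 to compound 3 (0.60 log units; beyond the scatter), which leaves compound 1 alone among the three at this position. Nothing available explains this separation.

Open, on these data alone, is whether 2-chlorophenyl would read like 2-bromophenyl in this assay. Also open, as far as these compounds go, is how a phenyl group carrying an amine or a carboxylic acid would read.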